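Triazole aryl swap in a weakly antiproliferative spirooxindole series

The source may report more compounds than this note shows. Statements on the series, on what has been measured and on what is new or still open speak of the compounds shown alone.

Compounds measured in an ADME assay on L02 cells (Homo sapiens) for antiproliferative activity, read by MTT assay, with a stated time of 48 h; a lower number here means a stronger inhibitor, a higher number a weaker inhibitor:
- compound 1, `Cc1ccc(-n2nncc2CN2C(=O)C3(C(C#N)=C(N)Oc4c3c3nc5ccccc5nc3c3ccccc43)c3ccccc32)cc1C`; here compound 1 returns only the assay limit, > 50000 nM.
- compound 2, `N#CC1=C(N)Oc2c(N)cc3nc4ccccc4nc3c2C12C(=O)N(Cc1cnnn1-c1cccc(C(F)(F)F)c1)c1ccccc12`; compound 2 gives 38100 nM.
- compound 3, `COc1ccccc1-n1nncc1CN1C(=O)C2(C(C#N)=C(N)Oc3c(N)cc4nc5ccccc5nc4c32)c2ccccc21`; compound 3 returns only the assay limit, > 50000 nM.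

Compound 3 therefore stands at the ceiling of this assay rather than at a number, and it shares that position with compound 1, as the limit of > 50000 nM in this assay, at which 2 of the 3 values shown sit, records. Among the measured compounds shown here, the single step that touches it, an at least 1.3-fold higher number from compound 2 to compound 3 (0.11 log units; that floor lies within the scatter), is a floor that lies within the scatter, so the two values give no direction beyond repeat variation.

Compound 4, `Cc1ccc(-n2nncc2CN2C(=O)C3(C(C#N)=C(N)Oc4c(N)cc5nc6ccccc6nc5c43)c3ccccc32)cc1Cl`, is not yet measured. It differs from compound 3 by 3-chloro-4-methylphenyl in place of 2-methoxyphenyl on an aromatic nitrogen.

For the measured compounds named here, no measured step exchanges one aryl group on the triazole nitrogen for a halogenated or methylated one within the same core, so the only bearing evidence is that every compound shown sits at or close to the limit, and the one step that exists, an at least 1.3-fold higher number from compound 2 to compound 3 (0.11 log units; that floor lies within the scatter), is within scatter. The expected step that the limit leaves unreadable from compound 3 to compound 4 is accordingly none beyond the scatter, with a limit read-out the most likely outcome. Compound 4 is estimated at 60000 nM, within 30000 nM to 150000 nM.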

Compound 4, half-maximal inhibitory concentration: > 50000 nM
Compound 4: only a limit was reported (the forecaster's own chance of this, stated with the estimate: 65%); the middle value is on the limit's open side.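

Notes on the aryl group on the aromatic nitrogen, read in this assay. A third aryl group on the same core, 3-chloro-4-methylphenyl, now gives a limit rather than a number, as 2-methoxyphenyl did in compound 3. Among the compounds shown here, the one readable new step is an at least 1.3-fold higher number from compound 2 to compound 4 (0.11 log units; that floor lies within the scatter), so 3-chloro-4-methylphenyl and 3-(trifluoromethyl)phenyl cannot be told apart at this position, and the step between compound 3 and compound 4 cannot be read, as both values are limits. With this result, the limit describes most of the compounds shown: the limit of > 50000 nM in this assay, at which 3 of the 4 values shown sit.

Compound 2 is the only compound here with a number, 38100 nM, and the compounds shown give no value that would rank the aryl groups at this position. Also open, as far as these compounds go, is how the read-out would respond to a group of a different kind, such as an aminomethyl or carboxylic acid substituent on the phenyl ring, or a plain butyl chain in place of the aryl group.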